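This account rests on a few compounds, and the source may have more. Where it says the series, first, only, none or still open, it means among the compounds named here.

Two compounds of the series have been run in an ADME assay on microsomes from liver (Homo sapiens) for metabolic stability, with a stated time of 10 min; on this read-out higher numbers stand for a more stable compound and lower numbers for a less stable compound. Compound 1 `CC(C)NCCS(=O)(=O)NC(=O)c1ccc(Nc2nc(NC3(c4ccc(Cl)cc4)CC3)nc(OCC(F)(F)F)n2)cc1` gives 89% in this assay. Compound 2 `CC(C)(C)OC(=O)NCCS(=O)(=O)NC(=O)c1ccc(Nc2nc(NC3(c4ccc(Cl)cc4)CC3)nc(OCC(F)(F)F)n2)cc1` gives 92% in this assay. Within the data shown here, the one step measured so far, a number 3 percentage points higher from compound 1 to compound 2 (within the scatter), stays within the scatter, so compound 2 and compound 1 cannot be told apart on this read-out; both sit high on the scale. Compound 3 `CC(C)C(=O)NCCS(=O)(=O)NC(=O)c1ccc(Nc2nc(NC3(c4ccc(Cl)cc4)CC3)nc(OCC(F)(F)F)n2)cc1` is not yet measured. It differs from compound 2 by isopropyl in place of tert-butoxy on a carbonyl carbon. Among the measured compounds shown here, only one measured step bears on this change, as it alters the same end of the molecule: a number 3 percentage points higher from compound 1 to compound 2 (within the scatter), a shift within the scatter. The expected step in this assay is therefore a number 4 percentage points lower from compound 2 to compound 3 (within the scatter), that is, none beyond the scatter. Compound 3 is expected to give 88% in this assay, with a range from 75% to 97%.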

Compound 3, percent of the compound remaining: 86%
The estimate for compound 3 lay 2 percentage points above the measured number; low and high end bracket the measured number.
By their numbers in this assay, from the lowest: compounds 3, 1 and 2 (each within the scatter of the next).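

In this assay, isopropyl in place of tert-butoxy on the carbonyl carbon gives a number 6 percentage points lower from compound 2 to compound 3 (within the scatter), and isopropylcarbonyl in place of isopropyl on the amine nitrogen gives a number 3 percentage points lower from compound 1 to compound 3 (within the scatter). With the isopropyl, tert-butoxycarbonyl and isopropylcarbonyl groups on this nitrogen, the three compounds now cannot be told apart on this read-out, so neither of the two acyl groups separates from the plain isopropyl amine here. No evidence at hand speaks to the reason for this.

As far as these compounds go, whether the same holds for a free primary amine, a carboxylic acid or a longer alkyl chain at this nitrogen remains open. Also open, from the compounds shown here alone, is whether a change in the shared core would leave this read-out just as flat.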